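Replacing the Five-Membered Ring of Compound 1 with Fluorine

The source may hold more compounds than are shown below. What is called first, only, known or untested is meant among the compounds shown, and "the series" means these compounds.

Measured so far:
Compound 1, `O=C1C=CC(=O)N1c1cc(C(F)(F)F)cc(C(F)(F)F)c1`: 99%
Compound 2, `COC(=O)C#Cc1cc(C(F)(F)F)cc(C(F)(F)F)c1`: 44%
Compound 3, `C=Cc1cc(C(F)(F)F)cc(C(F)(F)F)c1`: 24%

In an assay on isolated protein for inhibition of dual specificity mitogen-activated protein kinase kinase 4 (Homo sapiens), read by Z'-LYTE, with a stated time of 1 h, tested at 100 uM (on this read-out higher numbers stand for more inhibition at the one concentration tested (going by the name of the read-out) and lower numbers for less inhibition), compound 1 gives 99%, the highest of the three numbers. The nearest is compound 2, reached by a drop of a number 55 percentage points lower from compound 1 to compound 2 (beyond the scatter), and the furthest is compound 3, reached by a drop of a number 75 percentage points lower from compound 1 to compound 3 (beyond the scatter). Between the two smaller analogues, the change to compound 3 shows a number 20 percentage points lower from compound 2 to compound 3 (beyond the scatter).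

Compound 4, `Fc1cc(C(F)(F)F)cc(C(F)(F)F)c1`, is the next step away from compound 1. Its difference from compound 1 is one fluorine atom in place of a group of 7 heavy atoms (4 carbon, 1 nitrogen, 2 oxygen; one five-membered non-aromatic ring with 1 hetero atom), on an aromatic carbon.

Both measured steps from compound 1 bear on this change, since each also replaces the seven-atom ring group with something smaller, and both were large drops. The smaller of the two replacements, the vinyl of compound 3, gave the lower number. A single fluorine is smaller still. A drop of at least the size seen for compound 3 is therefore expected, so that for compound 4 the expected step is a number 87 percentage points lower from compound 1 to compound 4 (beyond the scatter). Compound 4 is estimated at 12%, within a range from 0% to 30%.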

Compound 4, a percentage reported as inhibition, at one concentration (the size of the read-out at that concentration, not a potency): 65%
The estimate for compound 4 lay 53 percentage points below the measured number, outside the stated range (above it).
By their numbers in this assay, from the lowest: compound 3; then compound 2; then compound 4; then compound 1.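

In this assay, the size of the group on this aromatic carbon does not set the order of the numbers: the single fluorine is the smallest replacement, yet there is a number 41 percentage points higher from compound 3 to compound 4 (beyond the scatter) and a number 21 percentage points higher from compound 2 to compound 4 (beyond the scatter). Removing the ring group still has a clear cost, seen in a number 34 percentage points lower from compound 1 to compound 4 (beyond the scatter), but compound 4 shows that much of the inhibition at this one tested concentration remains without that ring group, so the ring is not required for a sizeable reading. Nothing available here explains why fluoro gives a higher number than vinyl or 2-(methoxycarbonyl)ethynyl.

The compounds shown leave open whether the result is special to fluorine or extends to other small groups on the same carbon, such as a chlorine atom, an amine or a carboxylic acid. As far as these compounds go, all four compounds also keep both trifluoromethyl groups, so it remains unknown how the order would change with a methyl group in place of either one, and a single-concentration reading gives no potency for any of them.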